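Quinazoline sulfonamide series: aryl swap on the sulfonyl sulfur

The compounds below may be only part of what the source reports. "The series", "measured", "known", "first", "only" and "open" are said of these compounds alone.

Measured so far in a functional assay on PC-3 cells (Homo sapiens) for inhibition; a lower number here means a stronger inhibitor, a higher number a weaker inhibitor:
compound 1, `COc1ccc(C(=O)N2CCN(c3nc(N)c4cc(OC)c(OC)cc4n3)CC2)cc1OC`, 71000 nM
compound 2, `COc1cc2nc(N3CCN(C(=O)c4ccc(C(C)(C)C)cc4)CC3)nc(N)c2cc1OC`, 47000 nM
compound 3, `COc1cc2nc(N3CCN(S(=O)(=O)c4ccccc4[N+](=O)[O-])CC3)nc(N)c2cc1OC`, 35000 nM

Compound 3 sits at the low end of the three numbers. Compound 2 lies within the scatter of it, while compound 1 stands off from it by an amount beyond the scatter. All three share the same core and piperazine, and differ only in the aryl group carried on the carbonyl carbon or the sulfonyl sulfur.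

Compound 4, `COc1cc2nc(N3CCN(S(=O)(=O)c4ccc(S(C)(=O)=O)cc4)CC3)nc(N)c2cc1OC`, is not yet measured. It differs from compound 3 in one place: 4-(methylsulfonyl)phenyl in place of 2-nitrophenyl on a sulfonyl sulfur.

Within the data shown here, the only measured step that bears on an aryl swap at this kind of attachment is a 1.5-fold lower number from compound 1 to compound 2 (0.18 log units; within the scatter), which was a change on a carbonyl carbon rather than on a sulfonyl sulfur. Among the measured compounds shown here, no measured step addresses a sulfonyl-bound aryl directly. Given that precedent, the step to compound 4 is expected to be small, with no direction beyond the scatter, so the estimate is a 1.1-fold higher number from compound 3 to compound 4 (0.06 log units; within the scatter). Compound 4 is therefore estimated at 40000 nM in this assay, with a range from 15000 nM to 100000 nM.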

Compound 4, half-maximal inhibitory concentration: 17000 nM
Beside the measured number, compound 4's estimate is 2.4-fold (0.37 log units) above it, and the stated range covers the measured number.
By their numbers in this assay, from the lowest: compound 4; then compounds 3, 2 and 1 (each within the scatter of the next, the first and the last beyond it).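

In this assay, among these compounds, the aryl group on the sulfonyl sulfur gives the only step that lies beyond the scatter: 4-(methylsulfonyl)phenyl in place of 2-nitrophenyl gives a 2.1-fold lower number from compound 3 to compound 4 (0.31 log units; beyond the scatter). The aryl swap on the carbonyl carbon, a 1.5-fold lower number from compound 1 to compound 2 (0.18 log units; within the scatter), stayed within the scatter, so the sulfonyl-bound aryl is the first site shown to respond to a swap, though only modestly and on the strength of one pair. Nothing available explains this step.

Open, on these data alone, is whether a plain phenyl on the sulfonyl sulfur, or a phenyl carrying an amine or a carboxylic acid, would fall with compound 3 or with compound 4. Also open is what the sulfonyl link itself contributes relative to the carbonyl, as the compounds shown carry different aryl groups on the two links.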